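Adding a dimethylcarbamoyl to the core of compound 1

This account rests on a few compounds, and the source may have more. Where it says the series, first, only, none or still open, it means among the compounds named here.

Compound 1 `CCCn1c(SCc2cc([N+](=O)[O-])ccc2OC)nc2cc(NC(=O)NC(C)(C)C)ccc21` gives 18 nM in an assay on isolated protein for inhibition of Gonadotropin-releasing hormone receptor (Homo sapiens); a lower number here means a stronger inhibitor, a higher number a weaker inhibitor. Compound 2 `COCCn1c(SCc2cc([N+](=O)[O-])ccc2OC)nc2cc(NC(=O)NC(C)(C)C)ccc21` gives 57 nM. Compound 3 `COc1ccc([N+](=O)[O-])cc1CSc1nc2cc(NC(=O)NC(C)(C)C)ccc2n1Cc1ccccn1` gives 43 nM.

Compound 1 has the lowest number of the three: from compound 1 to compound 2 the number rises, a 3.2-fold higher number from compound 1 to compound 2 (0.50 log units; beyond the scatter), and from compound 1 to compound 3 it rises, a 2.4-fold higher number from compound 1 to compound 3 (0.38 log units; beyond the scatter). Both measured steps alter the group on the aromatic nitrogen of the shared core. Compound 4 `CCCn1c(SCc2cc([N+](=O)[O-])ccc2OC)nc2cc(NC(=O)NC(C)(C)C)cc(C(=O)N(C)C)c21` differs from compound 1 elsewhere: dimethylcarbamoyl in place of hydrogen on an aromatic carbon. Among the measured compounds shown here, no measured step touches this aromatic carbon, so the direction is unsupported by the data. Compound 4 is therefore expected to give 25 nM, with a range from 6 nM to 110 nM, a step of a 1.4-fold higher number from compound 1 to compound 4 (0.14 log units; within the scatter) that may fall within the scatter.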

Compound 4, half-maximal inhibitory concentration: 270 nM
The estimate for compound 4 lay 11-fold (1.03 log units) below the measured number; the measured number lies above the stated range.
By their numbers in this assay, from the lowest: compound 1; then compounds 3 and 2 (each within the scatter of the next); then compound 4.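

In this assay, among the compounds shown here, dimethylcarbamoyl in place of hydrogen on this aromatic carbon, ortho to a fused ring, is the first measured change at this position (a 15-fold higher number from compound 1 to compound 4 (1.18 log units; beyond the scatter)). This large step exceeds both measured changes on the aromatic nitrogen (a 3.2-fold higher number from compound 1 to compound 2 (0.50 log units; beyond the scatter); a 2.4-fold higher number from compound 1 to compound 3 (0.38 log units; beyond the scatter)), so this carbon responds more strongly to this substitution than that nitrogen did to its replacements. No evidence available accounts for the rise.

On these data alone, whether the rise is specific to dimethylcarbamoyl remains open, and a methyl, a fluorine or a carboxylic acid on this carbon would test that. As far as these compounds go, it is also open whether the step would be the same with the methoxyethyl of compound 2 or the pyridin-2-ylmethyl of compound 3 on the aromatic nitrogen.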